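This account rests on a few compounds, and the source may have more. Where it says the series, first, only, none or still open, it means among the compounds named here.

Compound 1 `CNC(=O)c1cc(Oc2ccc(C3=NNC(c4ccc(F)cc4Cl)C3)cc2)ccn1`: 11500 nM
Compound 2 `CNC(=O)c1cc(Oc2ccc(C3=NNC(c4ccc(Cl)c(Cl)c4)C3)cc2)ccn1`: 14400 nM
Compound 3 `CNC(=O)c1cc(Oc2ccc(C3=NNC(c4ccc(F)cc4)C3)cc2)ccn1`: 5280 nM

All three values come from a functional assay on HepG2 cells (Homo sapiens) for cytotoxicity, read by MTT assay, with a stated time of 72 h; on this read-out lower numbers stand for stronger inhibition and higher numbers for weaker inhibition. Compound 3 has the lowest number of the three, and its lead over each of the others lies beyond the usual scatter of repeat measurements. The next compound, compound 4 `CNC(=O)c1cc(Oc2ccc(C3=NN(C(N)=S)C(c4ccc(F)cc4)C3)cc2)ccn1`, keeps everything in compound 3 except for one change on an amine nitrogen in a ring: a group of 3 heavy atoms (1 carbon, 1 nitrogen, 1 sulfur; no ring) in place of a hydrogen atom, on an amine nitrogen in a ring.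

The measured steps offer only indirect guidance. Two are modest: a 2.2-fold lower number from compound 1 to compound 3 (0.34 log units; beyond the scatter) and a 2.7-fold lower number from compound 2 to compound 3 (0.44 log units; beyond the scatter). The third, a 1.3-fold higher number from compound 1 to compound 2 (0.10 log units; within the scatter), stays within the scatter. All of them involve the substituents on the aromatic ring carried by a saturated ring carbon, and none touches the amine nitrogen in a ring. The series therefore shows how far this assay moved for small edits elsewhere, but it gives no direction for this new group. With no evidence for either direction, no clear shift from compound 3 is expected, and the uncertainty is wide. The expected change is a 1.2-fold lower number from compound 3 to compound 4 (0.07 log units; within the scatter). For compound 4, the estimated value is 4500 nM, with an expected range from 1200 nM to 17000 nM.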

Compound 4, half-maximal inhibitory concentration: > 50000 nM
Compound 4: no number, only a limit; the forecaster's own chance of this, stated with the estimate: 8%; middle value at least 11-fold (1.04 log units) away from the limit.
By their numbers in this assay, from the lowest: compound 3; then compounds 1 and 2 (each within the scatter of the next). At a limit, above all of these: compound 4.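

Compound 4 gives no number in this assay, only a limit of the assay: the limit of > 50000 nM in this assay, at which 1 of the 4 values shown sits.

Placing the group of 3 heavy atoms (1 carbon, 1 nitrogen, 1 sulfur) on the amine nitrogen in a ring, in place of a hydrogen atom, gives an at least 9.4-fold higher number from compound 3 to compound 4 (0.97 log units; beyond the scatter), and this step is larger than the biggest step among the earlier compounds, a 2.7-fold lower number from compound 2 to compound 3 (0.44 log units; beyond the scatter). Within the data shown here, the earlier compounds changed only the aromatic ring on the saturated ring carbon, so this is the first sign that the assay responds strongly to a change at the ring nitrogen, with the hydrogen-bearing compound 3 giving the lower number of this pair. Since compound 4 stands at a limit, the step has a known minimum but no known full size.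

One compound cannot show whether the drop comes from the sulfur, from the terminal amine, or from any group at all on this nitrogen, and a methyl or an acetyl group, or a carboxamide with oxygen in place of sulfur, would help to separate these. As far as these compounds go, it also remains open whether the same change behaves alike when the 4-fluorophenyl group is replaced by the 2-chloro-4-fluorophenyl or 3,4-dichlorophenyl group.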